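Swapping a Cyclobutylmethyl Ether for an Oxazolyl Ethyl Ether

The compounds below may be only part of what the source reports. "The series", "measured", "known", "first", "only" and "open" are said of these compounds alone.

Measured so far:
- compound 1, `Cc1ccc([C@@H](C)Oc2cc3onc(CCC(=O)O)c3cc2Cl)nc1`: 1.59 nM
- compound 2, `O=C(O)CCn1c(=O)oc2cc(OCC3CCC3)c(Cl)cc21`: 1260 nM

Of the compounds shown here, two have been tested in an assay on HEK293 cells for inhibition of kynurenine 3-monooxygenase (Homo sapiens), read by LC-MS, with a stated time of 20 h; a higher number here means a weaker inhibitor, a lower number a stronger inhibitor. Compound 1 gives 1.59 nM in this assay, while compound 2 gives 1260 nM. Compound 2 therefore has the highest number of the two, and its gap to compound 1 lies well beyond the scatter, so compound 2 is clearly the weaker inhibitor of the pair. The two share no single-point relation, so the difference between them cannot be traced to one change.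

Compound 3, `C[C@@H](Oc1cc2oc(=O)n(CCC(=O)O)c2cc1Cl)c1ncco1`, is the next step, built from compound 2 by a single exchange: a group of 7 heavy atoms (5 carbon, 1 nitrogen, 1 oxygen; one five-membered aromatic ring with 2 hetero atoms) in place of a group of 5 heavy atoms (5 carbon; one four-membered non-aromatic ring of carbon only), on an oxygen on an aromatic ring

The entering group carries a defined stereocentre and a five-membered aromatic ring with two hetero atoms, which brings compound 3 closer in shape to the ether side chain of compound 1. Since compound 1 reaches 1.59 nM in this assay, a move toward a lower number is expected, and the step of a 32-fold lower number from compound 2 to compound 3 (1.50 log units; beyond the scatter) is expected to lie beyond the scatter. Compound 3 is therefore estimated at 40 nM, within a range of 6 nM to 300 nM.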

Compound 3, half-maximal inhibitory concentration: 7940 nM
The estimate for compound 3 lay 200-fold (2.30 log units) below the measured number; measured number above the stated range.
By their numbers in this assay, from the lowest: compound 1; then compound 2; then compound 3.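

In this assay, exchanging cyclobutylmethyl, on an oxygen on an aromatic ring, for the group of 7 heavy atoms with a five-membered aromatic ring with 2 hetero atoms gives a 6.3-fold higher number from compound 2 to compound 3 (0.80 log units; beyond the scatter). The step is modest but beyond the scatter, so the result at this position depends on which group the oxygen carries, and this particular exchange gives a weaker inhibitor. It also shows that adding an aromatic ring with 2 hydrogen-bond acceptors and a defined stereocentre at this position does not by itself give a stronger inhibitor on this core, and nothing measured here explains why the number rises.

Because several features change together in this one exchange, the step cannot separate the effect of the ring from that of the stereocentre or the added heavy atoms. A simple benzyl group on the same oxygen, or the mirror-image form of the entering group, would help show which of these features matters, and whether the change in this step comes from the ring itself or from its attachment.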